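The compounds below may be only part of what the source reports. "The series", "measured", "known", "first", "only" and "open" are said of these compounds alone.

Compound 3 `Nc1ccn([C@@H]2O[C@H](COP3(=O)OCC[C@H](c4cccnc4)O3)[C@@H](O)[C@@H]2O)c(=O)n1` sits at the top of the two single numbers available in a physicochemical assay for solubility, at pH 4 (a higher number here means a more soluble compound, a lower number a less soluble compound), where compound 3 gives 172000 ug/mL. Its nearest neighbour is compound 1 `Nc1ccn([C@@H]2O[C@H](COP3(=O)OCC[C@H](c4ccc(F)c(Cl)c4)O3)[C@@H](O)[C@@H]2O)c(=O)n1`, which in this assay gives 6700 ug/mL; the step of a 26-fold higher number from compound 1 to compound 3 (1.41 log units; beyond the scatter) shows how much the pyridin-3-yl group raised the number over the 3-chloro-4-fluorophenyl group on the same saturated ring carbon. Compound 2 `Nc1ccn([C@@H]2O[C@H](COP3(=O)OCC[C@H](c4ccncc4)O3)[C@@H](O)[C@@H]2O)c(=O)n1`, with a pyridin-4-yl group in the same place, gives 37900 ug/mL; > 200000 ug/mL (2 entries) in this assay across several entries.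

Compound 4 `COC(=O)c1cccc([C@H]2CCOP(=O)(OC[C@H]3O[C@@H](n4ccc(N)nc4=O)[C@@H](O)[C@@H]3O)O2)c1` differs from compound 3 in one place: 3-(methoxycarbonyl)phenyl in place of pyridin-3-yl on a saturated ring carbon. Among the measured compounds shown here, only one measured step bears on this change, the step from compound 1 to compound 3, and it was large. The change to compound 4 goes the other way, from a pyridin-3-yl ring back to an aromatic ring of carbon only, now carrying a methoxycarbonyl group rather than the chlorine and fluorine of compound 1. A drop in this assay is therefore expected for compound 4, though probably less steep than the full return to the level of compound 1. The expected step is an 8.6-fold lower number from compound 3 to compound 4 (0.93 log units; beyond the scatter), and compound 4 is estimated at 20000 ug/mL, with a range from 5000 ug/mL to 80000 ug/mL.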

Compound 4, solubility: 10300 ug/mL
Compound 4: the middle estimate sits 1.9-fold (0.29 log units) above what was measured, and the stated range covers the measured number.
By their numbers in this assay, from the lowest: compounds 1 and 4 (each within the scatter of the next); then compound 3.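

The step of a 17-fold lower number from compound 3 to compound 4 (1.22 log units; beyond the scatter) shows, in this assay, that the high number of compound 3 does not survive when a different aromatic ring of carbon only replaces pyridin-3-yl on this saturated ring carbon. The step of a 1.5-fold higher number from compound 1 to compound 4 (0.19 log units; within the scatter) lies within the scatter, which means that 3-(methoxycarbonyl)phenyl and 3-chloro-4-fluorophenyl cannot be told apart here, even though the two rings carry quite different substituents; among compounds 1, 3 and 4, the one with a ring nitrogen stands well clear of the two with carbon-only rings. The measurements shown give no direct evidence of what lies behind these differences.

As far as these compounds go, it remains open whether only a ring nitrogen can give a number as high as that of compound 3, or whether a carbon-only aromatic ring bearing an amine or a carboxylic acid could do the same. Also open, from the compounds shown here alone, is whether a non-aromatic ring such as piperidine at this position, or a longer chain between this ring carbon and the aromatic ring, would keep the number of compound 3 or lose it.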